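The source may hold more compounds than are shown below. What is called first, only, known or untested is meant among the compounds shown, and "the series" means these compounds.

Measured in a functional assay for inhibition, with Homo sapiens as the target; a lower number here means that less compound is needed, a higher number that more compound is needed for the effect:
Compound 1 `CCCCC(=O)Nc1ccc(C2=NNC(=O)CC2)cc1`: 2.64 ug/mL
Compound 2 `CN1N=C(c2ccc(N)cc2)CCC1=O`: > 46.4 ug/mL, a limit
Compound 3 `CC(=O)Nc1ccc(C2=NN(C)C(=O)CC2)cc1`: > 46.4 ug/mL, a limit

Going by the values given here, compound 1 holds the only actual number here, while the other two entries are the limit of > 46.4 ug/mL in this assay, at which 2 of the 3 values shown sit. Compound 4 `CC(C)(CCl)C(=O)Nc1ccc(C2=NNC(=O)CC2)cc1` keeps the core of compound 1 and carries one change, 1-(chloromethyl)-1-methylethyl in place of butyl on a carbonyl carbon. Among the compounds with values here, the one measured step, a step that the two limits leave unreadable from compound 2 to compound 3, has no readable size and does not swap one chain for another, so no measurement sizes this change. The expectation therefore stays anchored on compound 1 at 2.64 ug/mL, with no clear direction in this assay. The expected result is a 1.1-fold higher number from compound 1 to compound 4 (0.06 log units; within the scatter), which is no real shift. For compound 4 the estimated value is 3 ug/mL, with an expected range of 0.8 ug/mL to 12 ug/mL.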

Compound 4, half-maximal effective concentration: 11.4 ug/mL
Beside the measured number, compound 4's estimate is 3.8-fold (0.58 log units) below it; the range from low to high includes it.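

In this assay, putting 1-(chloromethyl)-1-methylethyl in place of butyl on a carbonyl carbon gives a 4.3-fold higher number from compound 1 to compound 4 (0.64 log units; beyond the scatter) and shows that this position responds to the chain it carries. Going by these compounds alone, this is the first readable step here, since the step between the two limits cannot be read, and compound 4 keeps a real number rather than a limit. Nothing shown gives a cause for this step. Still open, as far as these compounds go, is whether the chlorine or the branching carries the change, and how a longer chain such as hexyl, or an amine, would read on the same carbonyl carbon.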